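A few compounds are considered here, and "the series" means these few. Any claim that something is new, unique, unknown or untested is made for them only; others in the source may bear on it.

In a functional assay on the whole organism with Scenedesmus acutus as the target, with a stated time of 20 h (on this read-out higher numbers stand for weaker inhibition and lower numbers for stronger inhibition), the measured compounds read as follows

Compound 1 `O=C1C2=C(CCCC2)C(=O)N1c1ccc(Cl)cc1F` gives 240 nM
Compound 2 `CCOC(=O)c1cc(N2C(=O)C3=C(CCCC3)C2=O)c(F)cc1Cl` gives 87.1 nM
Compound 3 `CCOC(=O)c1cc(N2C(=O)C3=C(CCCC3)C2=O)ccc1Cl` gives 2140 nM

Compound 3 has the highest number of the three, which makes it the weakest inhibitor so far. Compound 4 `CC(C)(C)OC(=O)c1cc(N2C(=O)C3=C(CCCC3)C2=O)ccc1Cl` differs from it in one place, with tert-butyl in place of ethyl on an oxygen next to a carbonyl group as the full change.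

Going by the values given here, no measured step alters that ethyl. The closest evidence is a 2.8-fold lower number from compound 1 to compound 2 (0.44 log units; beyond the scatter), a modest step for adding the whole ethoxycarbonyl in place of hydrogen. The large 25-fold higher number from compound 2 to compound 3 (1.39 log units; beyond the scatter) instead put hydrogen in place of fluoro, so it says little here. A smaller change within that same group should therefore shift this assay little, in no firm direction. The estimated step is a 1.2-fold higher number from compound 3 to compound 4 (0.08 log units; within the scatter) and so nothing beyond the usual scatter is expected. The estimate for compound 4 is 2600 nM within an expected range of 900 nM to 7500 nM until the measurement arrives.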

Compound 4, half-maximal inhibitory concentration: > 100000 nM
Compound 4: no number, only a limit; the forecaster's own chance of this, stated with the estimate: 5%; middle value at least 38-fold (1.58 log units) away from the limit.
By their numbers in this assay, from the lowest: compound 2; then compound 1; then compound 3. At a limit, above all of these: compound 4.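

In this assay, the ester on this ring is far from indifferent to what sits on its oxygen: tert-butyl in place of ethyl gives an at least 46-fold higher number from compound 3 to compound 4 (1.66 log units; beyond the scatter). The earlier compounds shown here showed only what adding or removing whole groups does, whereas this change stays within the ethoxycarbonyl group and still has a large effect. Compound 4 has no number, only a limit: the limit of > 100000 nM in this assay, at which 1 of the 4 values shown sits.

The compounds shown leave open how isopropyl, a longer chain such as n-butyl, or the free carboxylic acid would read here. They also leave open whether the same change would act alike in compound 2, which carries the fluoro.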